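Trading a dimethoxyphenyl group for a dihydroxyphenyl group

This account rests on a few compounds, and the source may have more. Where it says the series, first, only, none or still open, it means among the compounds named here.

Of the compounds shown here, three that share one core have been tested in a functional assay on K562 cells (Homo sapiens) for antiproliferative activity, with a stated time of 72 h; on this read-out lower numbers stand for stronger inhibition and higher numbers for weaker inhibition. Compound 1 `OC[C@H]1O[C@@H](n2cnc3c(NCc4cccc(Br)c4)ncnc32)[C@H](O)[C@@H]1O` gives 19700 nM, and compound 2 `COc1ccccc1CNc1ncnc2c1ncn2[C@@H]1O[C@H](CO)[C@@H](O)[C@H]1O` gives 89000 nM. Compound 3 `COc1ccc(CNc2ncnc3c2ncn3[C@@H]2O[C@H](CO)[C@@H](O)[C@H]2O)c(OC)c1` is reported only as a limit, > 166000 nM.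

Compound 4 `OC[C@H]1O[C@@H](n2cnc3c(NCc4cccc(O)c4O)ncnc32)[C@H](O)[C@@H]1O` has not yet been measured. It differs from compound 3 on a saturated chain carbon bound to a nitrogen on an aromatic ring: 2,3-dihydroxyphenyl in place of 2,4-dimethoxyphenyl on a saturated chain carbon bound to a nitrogen on an aromatic ring.

The measured steps all change the group at this same place. Giving up the 3-bromophenyl group weakens inhibition, with a 4.5-fold higher number from compound 1 to compound 2 (0.65 log units; beyond the scatter) and an at least 8.4-fold higher number from compound 1 to compound 3 (0.92 log units; beyond the scatter). Adding one methoxy gives an at least 1.8-fold higher number from compound 2 to compound 3 (0.27 log units; that floor lies within the scatter). None of these steps introduces a hydroxy group, so they offer only loose guidance here.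

Compound 4 also lacks the 3-bromophenyl group, so a result in the region of compound 2 at 89000 nM is expected. Against the limit of compound 3, that would mean a modest move towards a lower number in this assay, though a second limit would be no surprise. The expected step is an at least 2.7-fold lower number from compound 3 to compound 4 (0.44 log units; beyond the scatter). Compound 4 is estimated at 60000 nM, with an expected range of 12000 nM to 170000 nM.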

Compound 4, half-maximal inhibitory concentration: 25800 nM
The estimate for compound 4 lay 2.3-fold (0.37 log units) above the measured number; measured number inside the range.
By their numbers in this assay, from the lowest: compounds 1 and 4 (each within the scatter of the next); then compound 2. At a limit, above all of these: compound 3.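

At this position, on a saturated chain carbon bound to a nitrogen on an aromatic ring, 2,3-dihydroxyphenyl is the one group shown without bromine that reaches the level of 3-bromophenyl in this assay: there is a 3.4-fold lower number from compound 2 to compound 4 (0.54 log units; beyond the scatter), while a 1.3-fold higher number from compound 1 to compound 4 (0.12 log units; within the scatter), so those two compounds cannot be told apart. A bromine on this ring is therefore not required for this level of inhibition, at least among these compounds, and the change away from the dimethoxy ring gives an at least 6.4-fold lower number from compound 3 to compound 4 (0.80 log units; beyond the scatter). As far as these compounds go, compound 3 is reported only as a limit, so that step is a floor and its true size stays unknown: the limit of > 166000 nM in this assay, at which 1 of the 4 values shown sits.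

The groups on compounds 2, 3 and 4 differ both in kind and in where they sit on the ring, so the compounds shown cannot say whether one hydroxy group or the pair accounts for the difference. A 3-hydroxyphenyl, a 2-hydroxyphenyl or a 2,3-dimethoxyphenyl group would separate these questions, and a 3-aminophenyl group would test whether an amine can stand in for the hydroxy.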